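A few compounds are considered here, and "the series" means these few. Any claim that something is new, unique, unknown or untested is made for them only; others in the source may bear on it.

Measured so far in an ADME assay on Vero cells (Chlorocebus sabaeus) for cytotoxicity; on this read-out higher numbers stand for lower toxicity in this test and lower numbers for higher toxicity in this test:
- Compound 1 `COc1cccc(-c2nc3c(NC4CCCC4)cccn3c2-c2ccnc(NC3CCCC3)n2)c1`: > 40000 nM (a limit)
- Compound 2 `N#Cc1cccc(-c2nc3c(NC4CCCC4)cccn3c2-c2ccnc(NC3CCCC3)n2)c1`: > 40000 nM (a limit)
- Compound 3 `CCCCNc1cccn2c(-c3ccnc(NC4CCCC4)n3)c(-c3ccc(F)cc3)nc12`: 32000 nM

For the measured compounds named here, compound 3 gives the only actual number in this assay, 32000 nM. Compound 1 and compound 2 both sit at a limit, (the limit of > 40000 nM in this assay, at which 2 of the 3 values shown sit).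

Compound 4 `Fc1ccc(-c2nc3ccccn3c2-c2ccnc(NC3CCCC3)n2)cc1` differs from compound 3 by hydrogen in place of butylamino on an aromatic carbon, with hydrogen in place of butylamino. Going by the values given here, the only measured step, a step that the two limits leave unreadable from compound 1 to compound 2, concerns a different group and offers no size to carry over. The expectation therefore rests on compound 3 at 32000 nM, which already lies low in toxicity on this scale. The expected change is a 1.2-fold higher number from compound 3 to compound 4 (0.07 log units; within the scatter), no step beyond the scatter, and if anything towards lower toxicity. Compound 4 is estimated at 38000 nM, with an expected range of 20000 nM to 60000 nM.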

Compound 4, half-maximal cytotoxic concentration: > 40000 nM
Compound 4: no number, only a limit (the forecaster's own chance of this, stated with the estimate: 60%); middle value at least 1.0-fold (0.02 log units) away from the limit.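

In this assay, hydrogen in place of butylamino on this aromatic carbon gives an at least 1.2-fold higher number from compound 3 to compound 4 (0.09 log units; that floor lies within the scatter). So removing the chain does not push the reading towards higher toxicity, and this is the first readable step at this position. Compound 4 gives a limit and not a number, so the true size of the step stays unknown, and it joins the other compounds at that limit: the limit of > 40000 nM in this assay, at which 3 of the 4 values shown sit.

On these data alone, whether a longer chain such as octylamino, or a carboxylic acid, on this carbon would lower the number remains open. Only a compound with a value below the limit could show that.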